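Swapping ethoxy for phenyl on a pyrrole polyene

The compounds below may be only part of what the source reports. "The series", "measured", "known", "first", "only" and "open" are said of these compounds alone.

Measured in a functional assay on CCRF-CEM cells (Homo sapiens) for cytotoxicity, with a stated time of 72 h; a lower number here means a stronger inhibitor, a higher number a weaker inhibitor:
- compound 1 `CCOC(=O)/C=C/C=C/C=C/c1ccc[nH]1` gives 3670 nM
- compound 2 `CCOC(=O)/C=C/C=C/C=C/c1[nH]ccc1Cl` gives 2420 nM

So far, compound 1 has only one measured neighbour, and the two values lie within the scatter of each other. The next compound to be tested is compound 3 `O=C(/C=C/C=C/C=C/c1ccc[nH]1)c1ccccc1`, which keeps the core of compound 1 but carries phenyl in place of ethoxy on a carbonyl carbon.

Among the measured compounds shown here, only one measured step is available, a 1.5-fold lower number from compound 1 to compound 2 (0.18 log units; within the scatter), and it puts chloro in place of hydrogen on an aromatic carbon. That is a different change in a different place, so it offers only weak guidance. For the measured compounds named here, no measured compound shows what a change on the carbonyl carbon does, and the direction in this assay stays open. The best guess is therefore no change beyond the scatter, held with wide uncertainty. The expected step is a 1.2-fold lower number from compound 1 to compound 3 (0.09 log units; within the scatter). For compound 3 the estimated value is 3000 nM, with an expected range from 700 nM to 12000 nM.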

Compound 3, half-maximal inhibitory concentration: 3070 nM
Beside the measured number, compound 3's estimate is 1.0-fold (0.01 log units) below it; the measured number falls inside the stated range.
By their numbers in this assay, from the lowest: compounds 2, 3 and 1 (each within the scatter of the next).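

Among the compounds shown here, the swap of phenyl for ethoxy gives a 1.2-fold lower number from compound 1 to compound 3 (0.08 log units; within the scatter) in this assay, so this is the first sign that the carbonyl carbon of the shared core can take a quite different group without a change beyond the scatter. The difference between the groups is sizeable on paper: ethoxy has 3 heavy atoms, no ring and 1 hydrogen-bond acceptor, while phenyl has 6 heavy atoms, a six-membered aromatic ring and no hydrogen-bond acceptor, yet that difference does not show up as a clear shift in this read-out. Nothing measured here explains the result, so it stands only as an observation.

On these data alone, it remains open whether any group on this carbonyl carbon can move the number beyond the scatter, for example an amine, a carboxylic acid or a longer chain. Also unresolved is whether chloro on an aromatic carbon would give a similarly small step in a compound that carries phenyl on the carbonyl carbon.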